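Lengthening the Alkoxy Chain on a Shared Core

The compounds below may be only part of what the source reports. "The series", "measured", "known", "first", "only" and "open" are said of these compounds alone.

Compound 1 `[O-][n+]1nc(NCOCc2ccc(C(F)(F)F)cc2)[n+]([O-])c2ccccc21` gives 9310 nM in a functional assay on PC-3 cells (Homo sapiens) for cytotoxicity, read by MTT assay, with a stated time of 72 h; a lower number here means a stronger inhibitor, a higher number a weaker inhibitor.
Compound 2 `COCNc1n[n+]([O-])c2ccccc2[n+]1[O-]` gives 4270 nM in this assay.
Compound 3 `COc1ccc2c(c1)[n+]([O-])nc(NCOC(C)c1ccccc1)[n+]2[O-]` gives > 100000 nM in this assay, which is a limit of the measurement and not a number.

Among the two real numbers, compound 2 stands lowest, and the next number, that of compound 1, is higher by a step beyond the usual scatter. Compound 4 `CCCCCOCNc1n[n+]([O-])c2ccccc2[n+]1[O-]` is built from compound 2 by a single change: butyl in place of hydrogen on a saturated chain carbon bound to an oxygen on a saturated carbon. Among the compounds with values here, no measured pair in this set differs by exactly this change, so the size of the step must be guessed from what is visible. Compound 1 carries a larger group on that same oxygen and shows a higher number than compound 2, and compound 3, with another large group there, gives only a limit. For compound 4 the expected step is a 2.1-fold higher number from compound 2 to compound 4 (0.32 log units; beyond the scatter), toward a weaker inhibitor, though the uncertainty is wide. Compound 4 is therefore estimated at 9000 nM, with a range from 3000 nM to 30000 nM.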

Compound 4, half-maximal inhibitory concentration: 8510 nM
Beside the measured number, compound 4's estimate is 1.1-fold (0.02 log units) above it; measured number inside the range.
By their numbers in this assay, from the lowest: compounds 2, 4 and 1 (each within the scatter of the next, the first and the last beyond it). At a limit, above all of these: compound 3.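

Within the data shown here, compound 4 gives the first step in this set that can be read between two compounds differing in one place: in this assay, the step is a 2.0-fold higher number from compound 2 to compound 4 (0.30 log units; within the scatter) for butyl in place of hydrogen on a saturated chain carbon bound to an oxygen on a saturated carbon. Going from methoxy to pentyloxy at this place therefore moves the number no further than repeated measurements of the same compound might, which no earlier pair could show. Nothing measured here points to a cause for this step.

As far as these compounds go, a single step cannot set a trend, so the behaviour of a propyl chain or of a chain longer than pentyloxy stays open. Also open, from the compounds shown here alone, is whether a chain ending in an amine or a carboxylic acid would fit this place as well.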